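Trimming tert-butyl to isopropyl

The source may hold more compounds than are shown below. What is called first, only, known or untested is meant among the compounds shown, and "the series" means these compounds.

In a functional assay on NCI-H460 cells (Homo sapiens) for cytotoxicity, read by MTT assay, with a stated time of 72 h (on this read-out lower numbers stand for stronger inhibition and higher numbers for weaker inhibition), compound 1 (`CC(C)(C)c1[nH]cnc1/C=c1\[nH]c(=O)/c(=C/c2cccc(C(=O)c3ccc(F)cc3)c2)[nH]c1=O`) gives 3.8 nM and compound 2 (`CC(C)(C)c1[nH]cnc1/C=c1\[nH]c(=O)/c(=C/c2cccc(Oc3ccc(F)cc3)c2)[nH]c1=O`) gives 4 nM, so these two values cannot be told apart. Compound 3 (`CC(C)c1[nH]cnc1/C=c1\[nH]c(=O)/c(=C/c2cccc(Oc3ccc(F)cc3)c2)[nH]c1=O`) differs from compound 2 by hydrogen in place of methyl on a saturated chain carbon bound to an aromatic carbon and two saturated chain carbons, which turns tert-butyl into isopropyl. Among the measured compounds shown here, the only measured step, a 1.1-fold higher number from compound 1 to compound 2 (0.02 log units; within the scatter), exchanges (4-fluorophenyl)carbonyl for 4-fluorophenoxy and leaves tert-butyl untouched, so it offers little direct guidance here. The expected step in this assay is modest, toward weaker inhibition: a 2.0-fold higher number from compound 2 to compound 3 (0.30 log units; within the scatter). Compound 3 is estimated at 8 nM, with an expected range of 3 nM to 22 nM.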

Compound 3, half-maximal inhibitory concentration: 8.8 nM
Beside the measured number, compound 3's estimate is 1.1-fold (0.04 log units) below it, and the stated range covers the measured number.
By their numbers in this assay, from the lowest: compounds 1 and 2 (each within the scatter of the next); then compound 3.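

Compound 2 and compound 3 are the first pair shown to differ at the tert-butyl group, and in this assay trimming it to isopropyl gives a 2.2-fold higher number from compound 2 to compound 3 (0.34 log units; beyond the scatter) and so moves the number beyond the scatter. This position therefore responds to the loss of one methyl, though only modestly, with compound 3 still at 8.8 nM in this assay. No evidence here explains the step.

On these data alone, it remains open whether ethyl or cyclopropyl at this place would shift the number further. As far as these compounds go, it is also open whether the same trim would give a similar step on compound 1, which carries (4-fluorophenyl)carbonyl instead of 4-fluorophenoxy.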